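This account rests on a few compounds, and the source may have more. Where it says the series, first, only, none or still open, it means among the compounds named here.

In a functional assay on PC-3 cells (Homo sapiens) for cytotoxicity, read by MTT assay, with a stated time of 72 h (on this read-out lower numbers stand for stronger inhibition and higher numbers for weaker inhibition), compound 1 `CCCCCCNc1nc(SCc2ccc(C(F)(F)F)cc2)nc2ccccc12` gives 19000 nM, compound 2 `COc1ccccc1Nc1nc(SCc2ccc(C(F)(F)F)cc2)nc2ccccc12` gives 14100 nM, and compound 3 `FC(F)(F)c1ccc(CSc2nc(Nc3cccc(Cl)c3)c3ccccc3n2)cc1` gives 13400 nM. Compound 3 sits apart from the other two only by a 1.4-fold lower number from compound 1 to compound 3 (0.15 log units; within the scatter) and by a 1.1-fold lower number from compound 2 to compound 3 (0.02 log units; within the scatter), both within the scatter. Compound 4 `Cc1ccc(Nc2nc(SCc3ccc(C(F)(F)F)cc3)nc3ccccc23)cc1` carries 4-methylphenyl in place of 3-chlorophenyl on a nitrogen on an aromatic ring. All three measured steps swap the group on this same nitrogen, namely a 1.3-fold lower number from compound 1 to compound 2 (0.13 log units; within the scatter), a 1.4-fold lower number from compound 1 to compound 3 (0.15 log units; within the scatter) and a 1.1-fold lower number from compound 2 to compound 3 (0.02 log units; within the scatter), and none reaches beyond the scatter. Given these flat steps, for compound 4 no step beyond the scatter is expected in this assay, that is a 1.0-fold higher number from compound 3 to compound 4 (0.02 log units; within the scatter). Compound 4 is estimated at 14000 nM in this assay, within a range from 6000 nM to 32000 nM.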

Compound 4, half-maximal inhibitory concentration: 21100 nM
Beside the measured number, compound 4's estimate is 1.5-fold (0.18 log units) below it, within the range that was stated.
By their numbers in this assay, from the lowest: compounds 3, 2, 1 and 4 (each within the scatter of the next).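

In this assay, 4-methylphenyl gives a fourth group on this nitrogen, and every new step stays within the scatter (a 1.6-fold higher number from compound 3 to compound 4 (0.20 log units; within the scatter)) (a 1.5-fold higher number from compound 2 to compound 4 (0.18 log units; within the scatter)) (a 1.1-fold higher number from compound 1 to compound 4 (0.05 log units; within the scatter)). The hexyl chain and the three substituted phenyl rings, now including one with a methyl group, therefore give numbers that cannot be told apart here. Nothing available gives a reason for this flatness. Still open, going by these compounds, is whether an amine or a carboxylic acid on this nitrogen's ring would move the number beyond the scatter. Also open, on these data alone, is whether changing the 4-trifluoromethylbenzyl group elsewhere on the shared core would do so.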